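The compounds below may be only part of what the source reports. "The series", "measured", "known", "first", "only" and "open" are said of these compounds alone.

Working notes on the series, read in a functional assay on PC-3 cells (Homo sapiens) for cytotoxicity; on this read-out lower numbers stand for stronger inhibition and higher numbers for weaker inhibition. Compound 1 (`CC(=O)Nc1[nH]nc2nnc(-c3ccccc3)c(-c3ccccc3)c12`) gives > 100000 nM, which is a limit of the assay and not a number. Compound 3 (`O=C(Nc1ccccc1)Nc1[nH]nc2nnc(-c3ccccc3)c(-c3ccccc3)c12`) gives > 100000 nM, which is likewise only a limit. For compound 2 (`Nc1[nH]nc2nnc(-c3ccc(-c4ccccc4)cc3)c(-c3ccc(-c4ccccc4)cc3)c12`) the entry is "not determined" (no result reported), so it adds nothing to the comparison. Among the measured compounds shown here, compound 3 thus has no number of its own, and no compound has yet given one.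

The next change leads to compound 4 (`CCNC(=O)Nc1[nH]nc2nnc(-c3ccccc3)c(-c3ccccc3)c12`), with ethyl in place of phenyl on an amide-type nitrogen. For the measured compounds named here, the one measured step that bears on it is a step that the two limits leave unreadable from compound 1 to compound 3, anilino in place of methyl on a carbonyl carbon, and its size cannot be read. The evidence amounts to the limit of > 100000 nM in this assay, at which 2 of the 3 values shown sit. Replacing the anilino of compound 3 with ethylamino gives a group that differs from both methyl and anilino, yet neither of those gave a number. No step beyond the scatter is therefore expected in this assay, in either direction, and a reported limit is the likeliest outcome. The expected step, a number no higher from compound 3 to compound 4 (the limit leaves the size open), is an estimate only. For compound 4 the estimated value is 100000 nM, with an expected range from 40000 nM to 200000 nM.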

Compound 4, half-maximal inhibitory concentration: > 100000 nM
Compound 4 was reported as a limit (the forecaster's own chance of this, stated with the estimate: 80%); the middle value sits exactly at the limit.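

In this assay compound 4 gives only a limit, so no step can be read among compound 1, compound 3 and compound 4, which all rest on the same limit: the limit of > 100000 nM in this assay, at which 3 of the 4 values shown sit. The compounds shown leave open how methyl, anilino and ethylamino on the carbonyl carbon compare, and whether any group there gives a number.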